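Compound 3 to compound 4: chloro in place of nitro

The source may hold more compounds than are shown below. What is called first, only, known or untested is meant among the compounds shown, and "the series" means these compounds.

In a functional assay on A549 cells (Homo sapiens) for cytotoxicity, read by MTT assay, with a stated time of 24 h (on this read-out higher numbers stand for weaker inhibition and lower numbers for stronger inhibition), compound 3 `C/C(=N\NC(=O)/C(C#N)=C/c1ccccc1[N+](=O)[O-])c1c(O)c2ccc(O)cc2oc1=O` gives 11400 nM. That lies within the scatter of compound 1 `COc1cc(/C=C(\C#N)C(=O)N/N=C(\C)c2c(O)c3ccc(O)cc3oc2=O)ccc1O` at 12600 nM. Compound 2 `C/C(=N\NC(=O)/C(C#N)=C/c1ccc(N(C)C)cc1)c1c(O)c2ccc(O)cc2oc1=O` gives 4310 nM, the smallest number of the three.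

Compound 4 `C/C(=N\NC(=O)/C(C#N)=C/c1ccccc1Cl)c1c(O)c2ccc(O)cc2oc1=O` has chloro in place of nitro on an aromatic carbon, ortho to a large group: chloro in place of nitro on an aromatic carbon. Among the measured compounds shown here, no measured step makes this exact change. The closest evidence is the replacement of whole aryl groups: a 1.1-fold lower number from compound 1 to compound 3 (0.04 log units; within the scatter), then a 2.9-fold lower number from compound 1 to compound 2 (0.47 log units; beyond the scatter) and a 2.6-fold higher number from compound 2 to compound 3 (0.42 log units; beyond the scatter), the last two modest. On that basis, no step beyond the scatter is expected in this assay. The estimated step is a 1.3-fold lower number from compound 3 to compound 4 (0.10 log units; within the scatter). Compound 4 is expected at 9000 nM, with an estimated range of 4500 nM to 16000 nM.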

Compound 4, half-maximal inhibitory concentration: 14200 nM
Beside the measured number, compound 4's estimate is 1.6-fold (0.20 log units) below it; measured number inside the range.
By their numbers in this assay, from the lowest: compound 2; then compounds 3, 1 and 4 (each within the scatter of the next).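

Working notes: in this assay, chloro in place of nitro on an aromatic carbon ortho to a large group leaves the number level (a 1.2-fold higher number from compound 3 to compound 4 (0.10 log units; within the scatter)). The 2-chlorophenyl of compound 4 is also level with the 4-hydroxy-3-methoxyphenyl of compound 1 (a 1.1-fold higher number from compound 1 to compound 4 (0.05 log units; within the scatter)), while the 4-(dimethylamino)phenyl of compound 2 stays apart (a 3.3-fold higher number from compound 2 to compound 4 (0.52 log units; beyond the scatter)). Nothing at hand gives a cause for either result.

Open: whether an amine or a carboxylic acid on this same aromatic carbon would leave the number level. Also open, as far as these compounds go, is whether chloro keeps this level when carried on another carbon of the ring.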